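This account rests on a few compounds, and the source may have more. Where it says the series, first, only, none or still open, it means among the compounds named here.

In an ADME assay on Vero 76 cells (Chlorocebus sabaeus) for cytotoxicity, read by MTT assay, with a stated time of 96 h (on this read-out higher numbers stand for lower toxicity in this test and lower numbers for higher toxicity in this test), two compounds that share one core have been measured so far. Compound 1 `Cc1ccccc1C1CC(c2ccc(OCc3ccccc3)cc2)=NN1c1ccc(S(N)(=O)=O)cc1` gives 100000 nM. Compound 2 `Cc1cccc(C2CC(c3ccc(OCc4ccccc4)cc3)=NN2c2ccc(S(N)(=O)=O)cc2)c1` gives 100000 nM, level with compound 1, its nearest neighbour on these numbers.

Compound 3 `NS(=O)(=O)c1ccc(N2N=C(c3ccc(OCc4ccccc4)cc3)CC2c2cccc(F)c2)cc1` is still unmeasured. Its difference from compound 2 is fluoro in place of methyl on an aromatic carbon. In words, this is fluoro in place of methyl on an aromatic carbon, so that 3-methylphenyl becomes 3-fluorophenyl.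

For the measured compounds named here, only one measured step bears on this change, and it is no change at the digits printed from compound 1 to compound 2 (within the scatter). Going by the values given here, that step shifts the methyl group on its ring and does not replace it, so the data hold no direct example of fluoro in this place. Among the compounds with values here, the evidence is therefore thin, but the one step available shows no movement, and the swap exchanges a single heavy atom for another. For this assay, the estimated change is no change at the digits printed from compound 2 to compound 3 (within the scatter), which means no step beyond the scatter is expected, in either direction. Compound 3 is expected to give about 100000 nM, with an estimated range of 45000 nM to 110000 nM.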

Compound 3, half-maximal cytotoxic concentration: 90000 nM
Estimate against measurement, compound 3: 1.1-fold (0.05 log units) above, within the range that was stated.
By their numbers in this assay, from the lowest: compounds 3, 1 and 2 (each within the scatter of the next).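

Fluoro in place of methyl on this aromatic carbon gives a 1.1-fold lower number from compound 2 to compound 3 (0.05 log units; within the scatter) in this assay, so this position now has a result for a group other than methyl, and the reading stays within the scatter. The earlier pair only moved the methyl group around its ring, whereas the step from the 2-methylphenyl to the 3-fluorophenyl compound, a 1.1-fold lower number from compound 1 to compound 3 (0.05 log units; within the scatter), alters both the group and where it sits, and that double change also stays within the scatter. No measurement shown here gives a reason for these results.

The compounds shown leave open whether a much larger or differently built group on this ring, such as an amine, a carboxylic acid or a longer alkyl chain, would read the same in this assay. For the compounds shown here, they also leave open whether any change at this position can move the reading beyond the scatter at all, since every step so far stays within it.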